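The source may report more compounds than this note shows. Statements on the series, on what has been measured and on what is new or still open speak of the compounds shown alone.

The three measured compounds and their values:
Compound 1, `C=C(C)[C@@H]1CC=C(Cn2cc(COc3ccc(C4NC(=O)NC(C)=C4C(C)=O)cc3)nn2)CC1`, 32700 nM
Compound 2, `C=C(C)[C@@H]1CC=C(Cn2cc(COc3ccc(C4NC(=O)NC(C)=C4C(C)=O)cc3OC)nn2)CC1`, 48000 nM
Compound 3, `C=C(C)[C@@H]1CC=C(Cn2cc(COc3ccc(C4NC(=O)NC5=C4C(=O)CC(C)(C)C5)cc3)nn2)CC1`, 29300 nM

All three were tested in a functional assay on OVCAR-3 cells (Homo sapiens) for inhibition, read by sulforhodamine B assay, with a stated time of 48 h; on this read-out higher numbers stand for weaker inhibition of growth and lower numbers for stronger inhibition of growth. Compound 2 differs from compound 1 by methoxy in place of hydrogen on an aromatic carbon, and that change gave a 1.5-fold higher number from compound 1 to compound 2 (0.17 log units; within the scatter). Compound 3 carries a different core; the difference between the core of compound 1 and the core of compound 3 is not broken down here. The values of compound 1, compound 2 and compound 3 all lie within the scatter of one another, so no order among the three can be read from these numbers.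

Compound 4, `C=C(C)[C@@H]1CC=C(Cn2cc(COc3ccc(C4NC(=O)NC5=C4C(=O)CC(C)(C)C5)cc3OC)nn2)CC1`, has not yet been measured in this assay. It differs from compound 3 by methoxy in place of hydrogen on an aromatic carbon, the same change as that between compound 1 and compound 2, made at the same place on the ring. The step from compound 3 to compound 4 is expected to be a 1.4-fold higher number from compound 3 to compound 4 (0.14 log units; within the scatter) in this assay, an expectation that rests on the earlier pair because a 1.5-fold higher number from compound 1 to compound 2 (0.17 log units; within the scatter) was observed. Compound 4 is therefore estimated at 40000 nM in this assay, within a range from 20000 nM to 80000 nM.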

Compound 4, concentration for total growth inhibition: 95000 nM
For compound 4 the middle estimate is 2.4-fold (0.38 log units) below the measured one; measured number above the stated range.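

In this assay, methoxy in place of hydrogen on an aromatic carbon gave a 3.2-fold higher number from compound 3 to compound 4 (0.51 log units; beyond the scatter). Set beside the same change on the core of compound 1, this step does not differ from the earlier one by more than the scatter allows: the same change on two cores in this assay, a 1.5-fold higher number (0.17 log units; within the scatter) from compound 1 to compound 2 and a 3.2-fold higher number (0.51 log units; beyond the scatter) from compound 3 to compound 4, 2.2-fold (0.34 log units) apart, within the scatter of two such steps The two pairs are therefore compatible with a single step carried from one core to the other, but they do not establish a shared size, since only the step on the core of compound 3 can be told from the scatter, and two pairs say nothing about any further core.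

The compounds shown leave open whether a hydroxyl, an ethoxy group, fluorine or an amine at the same place on the ring would give a step like that of methoxy. They also leave open whether any such replacement could bring the number lower than that of compound 3, at 29300 nM, on either core.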